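Replacing a Fluorophenyl Ether with a Pyridyl Ether

The source may report more compounds than this note shows. Statements on the series, on what has been measured and on what is new or still open speak of the compounds shown alone.

Compound 1 `COc1cc(OC)c2c(=O)cc(C(=O)Nc3ccc(Oc4ccc([N+](=O)[O-])cc4)cc3)[nH]c2c1` and compound 2 `COc1cc(OC)c2c(=O)cc(C(=O)Nc3ccc(Oc4ccc(F)cc4)cc3)[nH]c2c1` share one core and differ only in the group on the outermost aromatic ring. In a functional assay on SUP-B15 cells (Homo sapiens) for antiproliferative activity, with a stated time of 72 h (on this read-out lower numbers stand for an effect already at smaller amounts and higher numbers for an effect only at larger amounts of compound), compound 1 gives 4300 nM. For compound 2 this assay reports only a limit, > 50000 nM, not a number. Among the compounds with values here, the single measured step, an at least 11-fold higher number from compound 1 to compound 2 (1.06 log units; beyond the scatter), is therefore large, and compound 2 stands at the limit of > 50000 nM in this assay, at which 1 of the 2 values shown sits. Compound 3 `COc1cc(OC)c2c(=O)cc(C(=O)Nc3ccc(Oc4cccnc4)cc3)[nH]c2c1` alters compound 2 in a different way: pyridin-3-yl in place of 4-fluorophenyl on an oxygen on an aromatic ring. Within the data shown here, no measured step covers this exact exchange; the only one available shows that changing the group on this ring can move the number far in this assay, so a sizeable step in either direction remains open. Compound 3 is expected to show a step of an at least 1.4-fold lower number from compound 2 to compound 3 (0.15 log units; that floor lies within the scatter) from compound 2 in this assay. The estimate for compound 3 in this assay is 35000 nM, with a range from 7000 nM to 150000 nM.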

Compound 3, half-maximal effective concentration: > 32100 nM
Compound 3 gave a limit, no number; the forecaster's own chance of this, stated with the estimate: 55%; the middle value does not contradict the limit.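

In this assay compound 3 is reported only as a limit, not a number: the limit of > 32100 nM in this assay, at which 1 of the 3 values shown sits. Compound 2 is a limit too, so the step between compound 2 and compound 3 cannot be read: the limit of > 50000 nM in this assay, at which 1 of the 3 values shown sits. The one readable comparison is an at least 7.4-fold higher number from compound 1 to compound 3 (0.87 log units; beyond the scatter), so a second replacement of the 4-nitrophenyl group, this time by pyridin-3-yl on the same oxygen, also leaves no measured number, and among the three compounds shown only compound 1 has one.

Going by these compounds, it remains open whether a phenyl ring carrying a nitrile, an amine or a carboxylic acid in place of the nitro group would give a measured number in this assay. The compounds shown also leave open how a pyridin-4-yl or pyridin-2-yl group on this oxygen would behave.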